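Carboxy for methyl on the anilide ring of compound 2

This account rests on a few compounds, and the source may have more. Where it says the series, first, only, none or still open, it means among the compounds named here.

Measured compounds:
compound 1, `O=C(CSc1ccccc1C(=O)O)Nc1ccc(Br)cc1`, 9.04%
compound 2, `Cc1ccc(NC(=O)CSc2ccccc2C(=O)O)cc1`, 76.3%

In a functional assay on the whole organism (strain Swiss albino) for inhibition, with Mus musculus as the target, in the writhing test, with a stated time of 30 min, at a dose of 100 mg/kg by the intraperitoneal route (on this read-out lower numbers stand for less inhibition and higher numbers for more inhibition at the one dose given (going by the name of the read-out)), compound 2 stands highest of the two numbers, with compound 1 nearest and a number 67.3 percentage points higher from compound 1 to compound 2 (beyond the scatter), a large step from a single change on an aromatic carbon. Compound 3, `O=C(CSc1ccccc1C(=O)O)Nc1ccc(C(=O)O)cc1`, differs from compound 2 by carboxy in place of methyl on an aromatic carbon. Among the compounds with values here, no measured step covers a carboxy here; the one step known shows that this position can move the read-out widely. Compound 3 is therefore expected to lie below compound 2 with wide uncertainty, a number 36.3 percentage points lower from compound 2 to compound 3 (beyond the scatter), at an estimated 40% (range 10% to 75%).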

Compound 3, a percentage reported as inhibition, in the whole organism at one dose (the size of the read-out at that dose, not a potency): 20.3%
The estimate for compound 3 lay 19.7 percentage points above the measured number, within the range that was stated.
By their numbers in this assay, from the lowest: compound 1; then compound 3; then compound 2.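

In this assay carboxy in place of methyl gives a number 56 percentage points lower from compound 2 to compound 3 (beyond the scatter) and thus shows that a second group at this place, para to a large group, also sits far below methyl. Carboxy in place of bromo gives a number 11.3 percentage points higher from compound 1 to compound 3 (beyond the scatter) in a modest step, so among these three groups only methyl stands high. Nothing available explains this order. Going by these compounds, whether an amine or methoxy here would stay near methyl or fall toward carboxy remains open, as does the effect of a longer chain such as ethyl.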